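The source may hold more compounds than are shown below. What is called first, only, known or untested is meant among the compounds shown, and "the series" means these compounds.

Working notes on the series

All three measured compounds share one core and differ only in what stands on an oxygen on a saturated carbon. Compound 3 `CSc1cnc2ccccc2c1[Se]CC#CCOC(=O)c1ccccc1` carries a benzoyl there; in a functional assay on SW707 cells (Homo sapiens) for antiproliferative activity, with a stated time of 72 h (on this read-out lower numbers stand for stronger inhibition and higher numbers for weaker inhibition), compound 3 gives 3.6 ug/mL, the second highest of the three numbers, though all three lie within the scatter of one another. Compound 2 `CSc1cnc2ccccc2c1[Se]CC#CCO` has hydrogen in that place and in this assay compound 2 gives 3.4 ug/mL. Compound 1 `CSc1cnc2ccccc2c1[Se]CC#CCOC(=O)c1ccc(C(=O)O)cc1` carries carboxy on an aromatic carbon of the benzoyl and in this assay compound 1 gives 3.7 ug/mL. The two steps onto compound 3 are a 1.1-fold higher number from compound 2 to compound 3 (0.02 log units; within the scatter) and a 1.0-fold lower number from compound 1 to compound 3 (0.01 log units; within the scatter); neither rises above the scatter.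

Compound 4 `CSc1cnc2ccccc2c1[Se]CC#CCOC(=O)/C=C/c1ccccc1` differs from compound 3 in one place: 2-phenylethenyl in place of phenyl on a carbonyl carbon. Both measured steps bear on this, as each alters the same part of the molecule, and each left the number within the scatter. The step from compound 3 to compound 4 is therefore expected to be no change at the digits printed from compound 3 to compound 4 (within the scatter), with no change beyond the scatter in this assay. Compound 4 is estimated at 3.6 ug/mL, with a range from 2 ug/mL to 6.5 ug/mL.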

Compound 4, concentration for 50% inhibition: 4.7 ug/mL
Estimate against measurement, compound 4: 1.3-fold (0.12 log units) below, within the range that was stated.
By their numbers in this assay, from the lowest: compounds 2, 3, 1 and 4 (each within the scatter of the next).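

With 2-phenylethenyl on the carbonyl carbon in this assay, the change from phenyl gives a 1.3-fold higher number from compound 3 to compound 4 (0.12 log units; within the scatter) and the change from 4-carboxyphenyl gives a 1.3-fold higher number from compound 1 to compound 4 (0.10 log units; within the scatter) in the same series. The earlier steps shown here removed the benzoyl or altered its aromatic ring, whereas these two add a double bond outside the aromatic ring, and even so neither step rises above the scatter. No measurement to hand accounts for either step.

Still open, on these data alone, is whether any group on this oxygen moves the number beyond the scatter, for instance an acyl group carrying an amine or a longer saturated chain on the carbonyl carbon. Also open, as far as these compounds go, is whether a reduced side-chain double bond, as in a 2-phenylethyl group, would read the same as 2-phenylethenyl.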